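Triazole nitrogen substituent in a fused pyran series

A few compounds are considered here, and "the series" means these few. Any claim that something is new, unique, unknown or untested is made for them only; others in the source may bear on it.

The series shares the core seen in compound 1 `CCOC(=O)C1=Cc2ccccc2OC1(OCc1cn(-c2ccc(F)cc2)nn1)C(F)(F)F`, and activity is followed in a functional assay on A549 cells (Homo sapiens) for inhibition, read by MTT assay, with a stated time of 24 h; a lower number here means a stronger inhibitor, a higher number a weaker inhibitor. For the measured compounds named here, compound 1 gives 7300 nM there, the only measured number in the set. Compound 2 `O=C(O)C1=Cc2ccccc2OC1(OCc1cc(-c2ccc(F)cc2F)no1)C(F)(F)F` reaches only a limit of the assay, > 150000 nM. Compound 3 `CCOC(=O)C1=Cc2ccccc2OC1(OCc1cn(-c2cccc(C(F)(F)F)c2)nn1)C(F)(F)F` likewise reaches only a limit, > 150000 nM. Going by the values given here, the one step between measured compounds that differ in a single place is an at least 20-fold higher number from compound 1 to compound 3 (1.31 log units; beyond the scatter); it is the one piece of evidence on changing the group on the aromatic nitrogen, and it ends at the limit of > 150000 nM in this assay, at which 2 of the 3 values shown sit.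

Compound 4 `CCOC(=O)C1=Cc2ccccc2OC1(OCc1cn(CC(=O)Nc2cccc(F)c2)nn1)C(F)(F)F` differs from compound 1 in that same place: ((3-fluorophenyl)carbamoyl)methyl in place of 4-fluorophenyl on an aromatic nitrogen. Among the compounds with values here, no measured compound carries a carbamoyl-methyl group on that nitrogen, so the step from compound 1 is read only against the step to compound 3, where a change at the same nitrogen gave an at least large loss. On that basis a weakening in this assay is expected, and compound 4 is estimated at 40000 nM, between 8000 nM and 150000 nM. The expected step is a 5.5-fold higher number from compound 1 to compound 4 (0.74 log units; beyond the scatter), with a real chance that compound 4 also reports only a limit.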

Compound 4, half-maximal inhibitory concentration: > 150000 nM
Compound 4: no number, only a limit; the forecaster's own chance of this, stated with the estimate: 45%; middle value at least 3.7-fold (0.57 log units) from the limit.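

At the aromatic nitrogen of the five-membered ring, this assay now records a second large loss: an at least 20-fold higher number from compound 1 to compound 4 (1.31 log units; beyond the scatter). For the compounds shown here, until now a single replacement, 3-(trifluoromethyl)phenyl, was the only evidence at this nitrogen; ((3-fluorophenyl)carbamoyl)methyl, which brings 1 hydrogen-bond donor and 1 hydrogen-bond acceptor, goes the same way, so among the compounds that differ only here, 4-fluorophenyl in compound 1 alone gives a measured number. Compound 3 and compound 4 both report only a limit, so the step between them cannot be read, and the set now sits largely at one end of the assay: the limit of > 150000 nM in this assay, at which 3 of the 4 values shown sit.

Open, as far as these compounds go, is whether the loss in compound 4 follows from the carbamoyl-methyl link or from the aromatic ring it carries: a 3-fluorophenyl group or an unsubstituted phenyl on that nitrogen would help separate the two. Also open, from the compounds shown here alone, is how narrow the tolerance at this nitrogen is, since a 4-chlorophenyl or a benzyl group could show whether any replacement of 4-fluorophenyl keeps a measurable number.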